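The compounds below may be only part of what the source reports. "The series", "measured", "known", "first", "only" and "open" are said of these compounds alone.

In a physicochemical assay for lipophilicity, read by HPLC, at pH 7.5 (a lower number here means a more polar compound, a higher number a more lipophilic compound), three compounds built on a shared core have been measured. Compound 1 `CC[C@@H](Nc1c(C#N)c(-c2ccc(-c3ncccc3C)cc2)nc2cnccc12)C(N)=O` gives 2, compound 2 `CC[C@@H](Nc1c(C#N)c(-c2ccc(-c3cccc(Cl)c3OC)cc2)nc2cnccc12)C(N)=O` gives 3.1, and compound 3 `CC[C@@H](Nc1c(C#N)c(-c2ccc(-c3ccc(OC)cc3)cc2)nc2cnccc12)C(N)=O` gives 2.7. Compound 3 therefore holds the second highest of the three numbers, and its gaps to the other two both lie beyond the scatter.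

Compound 4 `CC[C@@H](Nc1c(C#N)c(-c2ccc(-c3cccc(Cl)c3)cc2)nc2cnccc12)C(N)=O` has not yet been measured. It differs from compound 3 in one place: 3-chlorophenyl in place of 4-methoxyphenyl on an aromatic carbon. Here 3-chlorophenyl stands in place of 4-methoxyphenyl on an aromatic carbon, para to a large group.

Among the compounds with values here, no measured step makes this exact exchange, so the evidence is indirect. The closest guide is the modest a number 0.40 log units lower from compound 2 to compound 3 (beyond the scatter), since the group in compound 2, 3-chloro-2-methoxyphenyl, shares its name's chloro part with the entering group. The other two steps, the large a number 1.10 log units higher from compound 1 to compound 2 (beyond the scatter) and the modest a number 0.70 log units higher from compound 1 to compound 3 (beyond the scatter), both start from 3-methylpyridin-2-yl and place the same two groups in the same order. Within the data shown here, no measured pair shows what losing the methoxy from 3-chloro-2-methoxyphenyl does alone, which widens the uncertainty.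

A modest rise is expected, and the estimated step is a number 0.50 log units higher from compound 3 to compound 4 (beyond the scatter). For compound 4 the expected value is 3.2, with an estimated range from 2.8 to 3.6.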

Compound 4, distribution coefficient: 3.1
Beside the measured number, compound 4's estimate is 0.10 log units above it; the measured number falls inside the stated range.
By their numbers in this assay, from the lowest: compound 1; then compound 3; then compounds 2 and 4 (each within the scatter of the next).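

Taking the methoxy off 3-chloro-2-methoxyphenyl, an exchange no earlier pair showed alone, gives no change at the digits printed from compound 2 to compound 4 (within the scatter) in this assay, so in these two compounds the methoxy leaves no reading that stands out from the scatter. The direct exchange of 4-methoxyphenyl for 3-chlorophenyl at this place, on an aromatic carbon para to a large group, gives a number 0.40 log units higher from compound 3 to compound 4 (beyond the scatter), and the exchange of 3-methylpyridin-2-yl for 3-chlorophenyl gives a number 1.10 log units higher from compound 1 to compound 4 (beyond the scatter); among these four compounds, the two that carry chlorine therefore both read above compound 3 and compound 1, with no exception in the set. Nothing available gives a measured reason for any of these steps.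

The compounds shown leave open what a plain phenyl, 4-chlorophenyl or 3-methoxyphenyl would give here, so the effect of the chlorine cannot yet be separated from that of where it or the methoxy sits on the ring. They also leave open how this assay would read with an amine or a carboxylic acid on the same ring, in place of the chloro or methoxy.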